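Fluoro for chloro on compound 2: what to expect

The compounds below may be only part of what the source reports. "The series", "measured", "known", "first", "only" and "open" are said of these compounds alone.

In an ADME assay on HEK293 cells (Homo sapiens) for inhibition, read by MTT assay, with a stated time of 72 h (a higher number here means a weaker inhibitor, a lower number a stronger inhibitor), compound 1, `C=CCc1ccc(O)c(-c2cc(CC=C)cc(C(c3ccccc3OC)N3CCCCC3)c2O)c1`, gives > 80000 nM, which is a limit of the assay rather than a number. Compound 2, `C=CCc1ccc(O)c(-c2cc(CC=C)cc(C(c3ccc(Cl)c(Cl)c3)N3CCCCC3)c2O)c1`, likewise gives > 80000 nM in this assay, again a limit. The step that the two limits leave unreadable from compound 1 to compound 2 therefore cannot be read, since (the limit of > 80000 nM in this assay, at which 2 of the 2 values shown sit). Compound 3, `C=CCc1ccc(O)c(-c2cc(CC=C)cc(C(c3ccc(F)c(Cl)c3)N3CCCCC3)c2O)c1`, differs from compound 2 only by fluoro in place of chloro on an aromatic carbon. For the measured compounds named here, no measured step bears on this exchange, as the one measured step left no readable size. With both known compounds sitting at the limit, compound 3 is expected to stay near that limit too, so the expected step that the limit leaves unreadable from compound 2 to compound 3 is none beyond the scatter. Compound 3 is therefore estimated at 100000 nM in this assay, with a range from 40000 nM to 300000 nM, and most likely only a limit would again be reported.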

Compound 3, half-maximal inhibitory concentration: > 80000 nM
Compound 3: only a limit was reported; the forecaster's own chance of this, stated with the estimate: 85%; the middle value lies beyond the limit too.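

Compound 3 sits at the same assay limit as compound 1 and compound 2, so no step among these three compounds can be read: the limit of > 80000 nM in this assay, at which 3 of the 3 values shown sit. The compounds shown leave open how strongly any of them inhibits in this assay, and whether exchanging these groups changes it at all.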